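Bromophenoxy positional step in a dihydrofolate reductase series

This account rests on a few compounds, and the source may have more. Where it says the series, first, only, none or still open, it means among the compounds named here.

Values in an assay on isolated protein for inhibition of Dihydrofolate reductase (Homo sapiens), read by spectrophotometry, using NADPH, with stated times of 5 s and 6 min, tested at 5 uM; on this read-out higher numbers stand for a stronger effect at the one concentration tested and lower numbers for a weaker effect:
compound 1 `NC1=NC2(CCOCC2)N(OCCCOc2ccc(F)cc2)C(N)=N1` gives > 90%; this is a limit of the assay, not a number (the limit of > 90% in this assay, at which 1 of the 3 values shown sits).
compound 2 `NC1=NC2(CCOCC2)N(OCCCOc2ccccc2Br)C(N)=N1` gives 83.8%.
compound 3 `NC1=NC2(CCOCC2)N(OCCCOc2cccc(Br)c2)C(N)=N1` gives 86.7%.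

Compound 3 holds the highest of the two numbers shown in this assay; its nearest neighbour is compound 2, and the gap a number 2.9 percentage points higher from compound 2 to compound 3 (within the scatter) sits within the scatter, so no order between them can be read. Against compound 1 only a floor is known: a number at least 3.3 percentage points lower from compound 1 to compound 3 (that floor lies within the scatter) and a number at least 6.2 percentage points lower from compound 1 to compound 2 (that floor lies within the scatter) both have floors inside the scatter.

Compound 4 `NC1=NC2(CCOCC2)N(OCCCOc2ccc(Br)cc2)C(N)=N1` is not yet measured. It differs from compound 3 by 4-bromophenyl in place of 3-bromophenyl on an oxygen on a saturated carbon. The step that bears on it most is a number 2.9 percentage points higher from compound 2 to compound 3 (within the scatter), which moved the bromophenyl from one position to another and stayed within the scatter. The floors from compound 1 to compounds 2 and 3 are also inside the scatter. Moving the bromine once more around the ring is therefore expected to give a step in this assay that stays within the scatter, in no clear direction, and the expected step is a number 0.3 percentage points higher from compound 3 to compound 4 (within the scatter).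

On that basis compound 4 is estimated at 87%, with a likely range from 78% to 94%.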

Compound 4, a percentage reported as inhibition, at one concentration (the size of the read-out at that concentration, not a potency): > 90%
Compound 4 ended at the assay's limit; the forecaster's own chance of this, stated with the estimate: 25%; middle value at least 3 percentage points away from the limit.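

Compound 4 sits at a limit of this assay, not at a number, and compound 1 sits at that same limit: the limit of > 90% in this assay, at which 2 of the 4 values shown sit.

The bromine series now has a member at the limit, but the positional steps carry only floors, a number at least 3.3 percentage points higher from compound 3 to compound 4 (that floor lies within the scatter) and a number at least 6.2 percentage points higher from compound 2 to compound 4 (that floor lies within the scatter), so neither change to 4-bromophenyl is shown to exceed the scatter, although the true size of each step remains unknown. The change from fluoro to bromo on the aromatic carbon cannot be read, so the 4-fluorophenyl and 4-bromophenyl compounds cannot be separated in this read-out.

Any real difference among the three bromophenyl isomers, or between compound 1 and compound 4, remains open at this single tested concentration. Also open, from the compounds shown here alone, is how an amine or a carboxylic acid on the aromatic ring, or a longer chain in place of the present saturated chain, would read in this assay.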